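Swapping methoxy for methylpiperazine on a weakly active series

This account rests on a few compounds, and the source may have more. Where it says the series, first, only, none or still open, it means among the compounds named here.

Of the compounds shown here, three sharing one core have been tested in a functional assay on MDA-MB-231 cells (Homo sapiens) for inhibition, read by MTT assay, with a stated time of 48 h; a higher number here means a weaker inhibitor, a lower number a stronger inhibitor. Compound 1 `COc1ccc(Nc2ncc3c(n2)N(C2CCCC2)CC(=O)N3C)cc1` carries a methoxy on its outer aromatic ring; in this assay compound 1 gives > 30000 nM, which is a limit of the assay rather than a number. Compound 2 `CCN1C(=O)CN(C2CCCC2)c2nc(Nc3ccc(OC)cc3)ncc21` differs from compound 1 by a methyl in place of hydrogen on a saturated chain carbon bound to an amide-type nitrogen in a ring; in this assay compound 2 gives > 30000 nM, again a limit and not a number. The step that the two limits leave unreadable from compound 1 to compound 2 is unreadable since both ends sit at the limit of > 30000 nM in this assay, at which 2 of the 3 values shown sit. Compound 3 `O=C1CN(C2CCCC2)c2nc(Nc3ccc(N4CCCCC4)cc3)ncc2N1` has a piperidinyl group in place of the methoxy and lacks the added methyl; in this assay compound 3 gives 25000 nM, a measured number. Compound 2 thus stands at the limit, where two of the three values sit.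

Compound 4 `CCN1C(=O)CN(C2CCCC2)c2nc(Nc3ccc(N4CCN(C)CC4)cc3)ncc21` is compound 2 with 4-methylpiperazin-1-yl in place of methoxy on an aromatic carbon. Among the measured compounds shown here, no measured step covers this exchange. The step of an at least 1.5-fold lower number from compound 2 to compound 4 (0.17 log units; that floor lies within the scatter) is expected to be a modest gain, because compound 3 gives 25000 nM with a cyclic amine in place of methoxy. Compound 4 is estimated at 20000 nM, within a range from 6000 nM to 60000 nM.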

Compound 4, half-maximal inhibitory concentration: 26200 nM
Compound 4: the middle estimate sits 1.3-fold (0.12 log units) below what was measured; low and high end bracket the measured number.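

On the core of compound 2, the place on an aromatic carbon, para to a large group, can hold 4-methylpiperazin-1-yl with activity still readable: in this assay compound 4 gives 26200 nM, a measured number rather than a limit. The exchange of methoxy for this larger ring group amounts to an at least 1.1-fold lower number from compound 2 to compound 4 (0.05 log units; that floor lies within the scatter), and a floor this small does not establish any real gain in strength. The true size of the step stays unknown, since one of its two ends is a limit of the assay and not a number: the limit of > 30000 nM in this assay, at which 2 of the 4 values shown sit.

Still open, as far as these compounds go, is whether other groups at this place, such as morpholine, a carboxylic acid or a longer chain ending in an amine, would bring the number clearly down in this assay. Also open, from the compounds shown here alone, is whether 4-methylpiperazin-1-yl would act in the same way on the core of compound 1, which differs from compound 2 by a single methyl.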